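The compounds below may be only part of what the source reports. "The series", "measured", "known", "first", "only" and "open" are said of these compounds alone.

Measured so far, in a functional assay on HL-60 cells (Homo sapiens) for antiproliferative activity, read by MTT assay, with a stated time of 72 h; a higher number here means a weaker inhibitor of growth, a lower number a stronger inhibitor of growth:
- compound 1 `CN(C)/[N+]([O-])=N/Oc1cc(O/N=[N+](\[O-])N2CCCC2CO)c([N+](=O)[O-])cc1[N+](=O)[O-]` gives 2000 nM
- compound 2 `CCN(CC)/[N+]([O-])=N/Oc1cc(O/N=[N+](\[O-])N(C)C)c([N+](=O)[O-])cc1[N+](=O)[O-]` gives 2300 nM
- compound 3 `CCOC(=O)N1CCN(/[N+]([O-])=N/Oc2cc(O/N=[N+](\[O-])N(CC)CC)c([N+](=O)[O-])cc2[N+](=O)[O-])CC1` gives 5000 nM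

Compound 3 holds the highest number of the three, separated from compound 2 by a 2.2-fold higher number from compound 2 to compound 3 (0.34 log units; beyond the scatter) and beyond the scatter from compound 1 as well. Compound 4 `CCN(CC)/[N+]([O-])=N/Oc1cc(O/N=[N+](\[O-])N2CCCC2CO)c([N+](=O)[O-])cc1[N+](=O)[O-]` differs from compound 3 by 2-(hydroxymethyl)pyrrolidin-1-yl in place of 4-(ethoxycarbonyl)piperazin-1-yl on a double-bonded nitrogen. Going by the values given here, two measured steps bear on this. The step of a 2.2-fold higher number from compound 2 to compound 3 (0.34 log units; beyond the scatter) shows that introducing the piperazinyl carbamate raised the number modestly, so removing it should be expected to lower it. The step of a 1.2-fold higher number from compound 1 to compound 2 (0.06 log units; within the scatter) shows no difference beyond the scatter when the hydroxymethylpyrrolidinyl is exchanged. Compound 4 is therefore expected to return to the level of compounds 1 and 2, a step of a 2.2-fold lower number from compound 3 to compound 4 (0.34 log units; beyond the scatter) downward. Compound 4 is estimated at 2300 nM, range 1200 nM to 4500 nM in this assay.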

Compound 4, concentration for total growth inhibition: 4000 nM
The estimate for compound 4 lay 1.7-fold (0.24 log units) below the measured number; the measured number falls inside the stated range.
By their numbers in this assay, from the lowest: compounds 1, 2, 4 and 3 (each within the scatter of the next, the first and the last beyond it).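

In this assay the exchange of 4-(ethoxycarbonyl)piperazin-1-yl for 2-(hydroxymethyl)pyrrolidin-1-yl shows a 1.3-fold lower number from compound 3 to compound 4 (0.10 log units; within the scatter) and stays within the scatter, so the piperazine carbamate does not stand apart from this group. With diethylamino shared, a 1.7-fold higher number from compound 2 to compound 4 (0.24 log units; within the scatter) also stays within the scatter, and with 2-(hydroxymethyl)pyrrolidin-1-yl shared, so does a 2.0-fold higher number from compound 1 to compound 4 (0.30 log units; within the scatter) at the other double-bonded nitrogen. No measurement offers an explanation for these results. Open is whether a piperazin-1-yl carrying a free ring amine, or a carboxylic acid in place of the hydroxymethyl, would stay within the scatter of these compounds.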